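The source may report more compounds than this note shows. Statements on the series, on what has been measured and on what is new or still open speak of the compounds shown alone.

Of the compounds shown here, three have been measured in a functional assay on B16 cells (Mus musculus) for antiproliferative activity, with a stated time of 72 h; on this read-out lower numbers stand for stronger inhibition and higher numbers for weaker inhibition. Compound 1 `CSc1cnc2ccccc2c1[Se]CC#CCOC(=O)c1ccc(C(=O)O)cc1` gives 3.1 ug/mL. Compound 2 `O=C(O)c1ccc(C(=O)OCC#CCSc2cnc3ccccc3c2Cl)cc1` gives 53.8 ug/mL. Compound 3 `CCOC(=O)OCC#CCSc1c(SC)cnc2ccccc12` gives 5.5 ug/mL. On these numbers compound 3 stands second highest of the three: its nearest neighbour is compound 1, whose number is lower by a step that stays within the scatter, while compound 2 is furthest, with a number higher by a step that lies beyond the scatter.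

The account now turns to compound 4 `CSc1cnc2ccccc2c1SCC#CCOC(=O)c1ccccc1`, which has not yet been measured in this assay. Compound 4 differs from compound 3 in one place: phenyl in place of ethoxy on a carbonyl carbon. Cut one bond further out, the same difference reads ethoxycarbonyl to benzoyl.

For the measured compounds named here, no pair of measured compounds differs in this single place, so no measured step shows what this change does. Compound 1 carries a benzoate bearing a carboxylic acid and gives 3.1 ug/mL, a number within the scatter of compound 3, and this is the nearest guide. For compound 4 the expected step of a 1.4-fold lower number from compound 3 to compound 4 (0.14 log units; within the scatter) is therefore small, not beyond the scatter, leaning if anything toward a lower number. Compound 4 is estimated at 4 ug/mL, with a likely range from 1.5 ug/mL to 11 ug/mL.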

Compound 4, concentration for 50% inhibition: 17.8 ug/mL
The estimate for compound 4 lay 4.5-fold (0.65 log units) below the measured number, outside the stated range (above it).
By their numbers in this assay, from the lowest: compounds 1 and 3 (each within the scatter of the next); then compound 4; then compound 2.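

In this assay, the step from ethoxy to phenyl on a carbonyl carbon is a 3.2-fold higher number from compound 3 to compound 4 (0.51 log units; beyond the scatter) and goes toward weaker inhibition. For the compounds shown here, this is the first single-place comparison, and it shows that the group on this carbonyl carbon is not indifferent: with the rest of the molecule held constant, ethoxycarbonyl and benzoyl read differently, although the step is modest. No measurement at hand bears on why the number rises with this change.

The compounds shown leave open whether the step goes with the ring that enters or with the oxygen that leaves: a phenoxy group on the same carbonyl carbon would carry both, and a propyl chain neither. On these data alone, how an amine or a longer alkoxy chain such as butoxy would read at this place also remains open, as does whether the step would keep its size alongside the other differences seen in compounds 1 and 2.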